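A few compounds are considered here, and "the series" means these few. Any claim that something is new, unique, unknown or untested is made for them only; others in the source may bear on it.

Measured in a functional assay on HOS-TE85 cells (Homo sapiens) for inhibition, read by CCK-8 assay, with a stated time of 72 h; a lower number here means a stronger inhibitor, a higher number a weaker inhibitor:
- Compound 1 `COc1ccccc1N1C(=O)CSC1c1cccc(C(=O)NCCCCn2cccn2)c1`: 91.7 nM
- Compound 2 `O=C(NCCCCn1cccn1)c1cccc(C2SCC(=O)N2c2ccccn2)c1`: 60.3 nM
- Compound 3 `O=C(NCCCCn1cccn1)c1cccc(C2SCC(=O)N2c2ccncc2)c1`: > 1000 nM, a limit of the assay

Compound 1 sits level with compound 2, with a 1.5-fold lower number from compound 1 to compound 2 (0.18 log units; within the scatter). Compound 3 gives only a limit, and the comparison with it shows an at least 10-fold higher number from compound 1 to compound 3 (1.03 log units; beyond the scatter).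

Compound 4 `COc1ccccc1N1C(=O)CSC1c1cccc(C(=O)NCCCCn2ccc3ccccc32)c1` keeps the core of compound 1 and differs only at the end of the chain: 1H-indol-1-yl in place of 1H-pyrazol-1-yl on a saturated chain carbon, four bonds along the chain from an amide-type nitrogen. In short, 1H-indol-1-yl stands in place of 1H-pyrazol-1-yl on a saturated chain carbon, four bonds along the chain from an amide-type nitrogen.

Within the data shown here, none of the measured steps touches this place. All of them change the group on an amide-type nitrogen in a ring, and they show only how far the numbers can move in this small set. That range runs from a 1.5-fold lower number from compound 1 to compound 2 (0.18 log units; within the scatter) to an at least 16-fold higher number from compound 2 to compound 3 (1.21 log units; beyond the scatter). The data therefore give no direction for the new change, and no step beyond the scatter is expected in this assay, although the uncertainty is wide.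

The estimate amounts to an expected 1.1-fold higher number from compound 1 to compound 4 (0.04 log units; within the scatter). Compound 4 is expected at 100 nM, with an estimated range from 25 nM to 500 nM.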

Compound 4, half-maximal inhibitory concentration: 286 nM
Estimate against measurement, compound 4: 2.9-fold (0.46 log units) below; the measured number falls inside the stated range.
By their numbers in this assay, from the lowest: compounds 2 and 1 (each within the scatter of the next); then compound 4. At a limit, above all of these: compound 3.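

In this assay, the change at the end of the chain gives a 3.1-fold higher number from compound 1 to compound 4 (0.49 log units; beyond the scatter), which shows that the numbers respond to the group carried on a saturated chain carbon, four bonds along the chain from an amide-type nitrogen. The earlier compounds shown here had varied only the group on the amide-type nitrogen in the ring, so they gave no reading of this place. The swap from 1H-pyrazol-1-yl to 1H-indol-1-yl brings in a six-membered aromatic ring of carbon only and leaves one nitrogen in the five-membered ring, and compound 4 still gives 286 nM, yet nothing measured here accounts for the step.

This single pair cannot separate the added six-membered ring from the lost ring nitrogen, and 1H-pyrrol-1-yl, a five-membered aromatic ring with one nitrogen, would bear on that question. As far as these compounds go, it also remains open whether the same swap would move the number similarly on the pyridin-2-yl group of compound 2, and how a longer chain or an amine at the chain end would read.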